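A few compounds are considered here, and "the series" means these few. Any claim that something is new, unique, unknown or untested is made for them only; others in the source may bear on it.

In an ADME assay on microsomes from liver (Homo sapiens) for metabolic stability (a higher number here means faster removal of the compound, a lower number slower removal), compound 1 `O=C(O)Cn1nc(Cn2cc3cc(OCC4CC4)c(Cl)cc3n2)c2ccccc2c1=O` is known only through a limit, < 25 mL/min/kg, and not through a number. Compound 1 thus stands at the limit of < 25 mL/min/kg in this assay, at which 1 of the 3 values shown sits. Two related compounds do carry numbers: compound 2 `CC(C)(C(=O)O)c1nn(Cc2cn3cc(OCC4CC4)c(Cl)cc3n2)c2ccccc2c1=O` gives 21.7 mL/min/kg, and compound 3 `C[C@H](C(=O)O)n1nc(Cn2cc3cc(OCC4CC4)c(Cl)cc3n2)c2ccccc2c1=O` gives 20 mL/min/kg.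

Compound 4 `CCOc1cc2cn(Cc3nn(CC(=O)O)c(=O)c4ccccc34)nc2cc1Cl` keeps the core of compound 1 and alters one group: methyl in place of cyclopropyl on a saturated chain carbon bound to an oxygen on an aromatic ring. In words, this is methyl in place of cyclopropyl on a saturated chain carbon bound to an oxygen on an aromatic ring, so that cyclopropylmethoxy becomes ethoxy.

Within the data shown here, the only measured step is a step that the limit leaves unreadable from compound 1 to compound 3. It places methyl in place of hydrogen on a saturated chain carbon bound to an aromatic nitrogen and a carbonyl carbon, which is a different place, and it offers no size to carry over. Among the measured compounds shown here, no measured step covers the change to compound 4, so the expectation leans on the nearby numbers, such as compound 3 at 20 mL/min/kg. The expected step, a step that the limit leaves unreadable from compound 1 to compound 4, is none beyond the scatter, with no direction claimed. For compound 4 the estimated clearance in this assay is 17 mL/min/kg, with an expected range from 9 mL/min/kg to 28 mL/min/kg.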

Compound 4, clearance: 35 mL/min/kg
Compound 4: middle estimate off by 2.1-fold (0.31 log units), on the low side, and the stated range ends below it.
By their numbers in this assay, from the lowest: compounds 3, 2 and 4 (each within the scatter of the next).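

The earlier compounds all carry cyclopropylmethoxy, so they showed nothing about this place, and their one listed step lies elsewhere on the molecule. In this assay, the change from cyclopropylmethoxy to ethoxy, with methyl in place of cyclopropyl, now gives an at least 1.4-fold higher number from compound 1 to compound 4 (0.14 log units; that floor lies within the scatter). Compound 1 has a limit and not a number, and this is because the step can be read only as a floor in the direction of faster removal, with no upper size: the limit of < 25 mL/min/kg in this assay, at which 1 of the 4 values shown sits.

It remains open whether the step follows the loss of the three-membered ring or the shortening of the chain, as ethoxy is the only replacement shown; a propoxy or a cyclobutylmethoxy group at this place would tell those two readings apart. Also open, as far as these compounds go, is whether the same change would give a step of similar direction on the core of compound 3, which carries an added methyl on the chain bearing the carboxylic acid.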